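This account rests on a few compounds, and the source may have more. Where it says the series, first, only, none or still open, it means among the compounds named here.

Notes on the series. Compound 1 `CCOC(=O)C1=Cc2ccccc2OC1(OCc1cc(-c2ccc(OC)cc2)no1)C(F)(F)F` carries the ethyl ester and the 4-methoxyphenyl group; in a functional assay on DU-145 cells (Homo sapiens) for inhibition, read by MTT assay, with a stated time of 24 h (a higher number here means a weaker inhibitor, a lower number a stronger inhibitor), compound 1 gives only a limit of the assay, > 150000 nM, not a number. Compound 2 `O=C(O)C1=Cc2ccccc2OC1(OCc1cc(-c2ccc(F)cc2)no1)C(F)(F)F` carries the free acid and the 4-fluorophenyl group; in this assay compound 2 gives 168000 nM. For the measured compounds named here, of the two values shown this is the only number, the other being a limit (the limit of > 150000 nM in this assay, at which 1 of the 2 values shown sits), so compound 2 stands alone as the sole measured point, and no step between measured compounds can be read from the data.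

Compound 3 `COc1ccc(-c2cc(COC3(C(F)(F)F)Oc4ccccc4C=C3C(=O)O)on2)cc1` keeps the free acid and differs from compound 2 in one place: methoxy in place of fluoro on an aromatic carbon. Going by the values given here, no measured step of this kind exists, so the size of such a step cannot be taken from the data. The expected step is a 1.1-fold higher number from compound 2 to compound 3 (0.03 log units; within the scatter), none beyond the scatter in either direction. Compound 3 is estimated at 180000 nM in this assay, with a range from 90000 nM to 360000 nM, and a limit rather than a number is a real possibility.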

Compound 3, half-maximal inhibitory concentration: 42000 nM
The estimate for compound 3 lay 4.3-fold (0.63 log units) above the measured number; measured number below the stated range.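

For the compounds shown here, with the free acid held, the change from 4-fluorophenyl to 4-methoxyphenyl, on an aromatic carbon para to a large group, gives the first measured step in this assay: a 4.0-fold lower number from compound 2 to compound 3 (0.60 log units; beyond the scatter). This shows that the position is not silent in this assay, and that methoxy, the group with one hydrogen-bond acceptor, goes with the lower number in this pair. With the 4-methoxyphenyl group held, hydrogen in place of ethyl on an oxygen next to a carbonyl group gives an at least 3.5-fold lower number from compound 1 to compound 3 (0.55 log units; beyond the scatter), and this size is only a bound because compound 1 has a limit of the assay rather than a number: the limit of > 150000 nM in this assay, at which 1 of the 3 values shown sits.

As far as these compounds go, whether the step at this position follows a wider trend stays open, as a single pair cannot show how a chloro group, a hydroxyl group, an amine or a longer alkoxy chain such as ethoxy would compare with fluoro and methoxy. Also open, from the compounds shown here alone, are the effect of the methoxy change on the ethyl ester and how an amide or a nitrile would compare with the free acid of compound 3.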